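Acrylamide tail variation on two quinazoline-amine cores

The compounds below may be only part of what the source reports. "The series", "measured", "known", "first", "only" and "open" are said of these compounds alone.

Two cores are compared here. Compound 1 `CC(C)=CC(=O)Nc1cc2c(N3CCc4ccccc43)ncnc2cc1O[C@@H]1CCOC1` carries a 2-methylprop-1-en-1-yl group on the carbonyl carbon, and in a functional assay on PC-3 cells (Homo sapiens) for antiproliferative activity, read by MTT assay, with a stated time of 72 h (on this read-out higher numbers stand for weaker inhibition and lower numbers for stronger inhibition), compound 1 gives 4620 nM. Compound 2 `C/C=C/C(=O)Nc1cc2c(N3CCc4ccccc43)ncnc2cc1O[C@@H]1CCOC1` differs from it by prop-1-en-1-yl in place of 2-methylprop-1-en-1-yl on a carbonyl carbon; in this assay compound 2 gives 5220 nM, so the change gives a 1.1-fold higher number from compound 1 to compound 2 (0.05 log units; within the scatter). Compound 3 `COc1cc2ncnc(N3CCCc4ccccc43)c2cc1NC(=O)C=C(C)C` has a different core, and the difference between the two cores is not broken down here; in this assay compound 3 gives 6130 nM. The three measured values all lie within the scatter of one another, so no order among them is claimed.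

Compound 4 `C/C=C/C(=O)Nc1cc2c(N3CCCc4ccccc43)ncnc2cc1OC` is the unmeasured member and differs from compound 3 by prop-1-en-1-yl in place of 2-methylprop-1-en-1-yl on a carbonyl carbon. The place line is the same word for word as for the change from compound 1 to compound 2, so this is the same change, made once before among the measured compounds. Because a 1.1-fold higher number from compound 1 to compound 2 (0.05 log units; within the scatter) stayed within the scatter, the step from compound 3 to compound 4 is expected to be of a similar small size, estimated as a 1.1-fold higher number from compound 3 to compound 4 (0.05 log units; within the scatter). For the measured compounds named here, the untested core of compound 3 adds uncertainty, since the change has been seen on only one core. The estimate for compound 4 in this assay is 6900 nM, expected to fall between 3000 nM and 15000 nM.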

Compound 4, half-maximal inhibitory concentration: 7520 nM
The estimate for compound 4 lay 1.1-fold (0.04 log units) below the measured number; the measured number falls inside the stated range.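

In this assay the exchange of 2-methylprop-1-en-1-yl for prop-1-en-1-yl on a carbonyl carbon gives a 1.2-fold higher number from compound 3 to compound 4 (0.09 log units; within the scatter) on the second core. Set beside the earlier step, the result on this core agrees with the first: the same change on two cores in this assay, a 1.1-fold higher number (0.05 log units; within the scatter) from compound 1 to compound 2 and a 1.2-fold higher number (0.09 log units; within the scatter) from compound 3 to compound 4, 1.1-fold (0.04 log units) apart, within the scatter of two such steps. For the compounds shown here, the change therefore carries from one core to the other in this assay without a detectable shift, but this rests on just two pairs whose steps both lie within the scatter, so it shows only that the exchange leaves the number within the scatter on these two cores, and it shows neither a real effect of the change nor how it would behave on any further core.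

From the compounds shown here alone, whether a tail with a larger difference, such as a dimethylamino group on the chain or a longer chain on the carbonyl carbon, would move the number beyond the scatter remains open. The separate contribution of the core also stays open, as the two cores differ in more than one place and no pair shown isolates any one of those differences.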